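A Methoxy Added to a Weakly Active Piperazine Phenyl

The compounds below may be only part of what the source reports. "The series", "measured", "known", "first", "only" and "open" are said of these compounds alone.

Measured compounds:
Compound 1, `COc1ccc(-c2nnc(N3CCN(C(=O)CN4CCN(c5cccc(Cl)c5)CC4)CC3)nc2-c2ccc(OC)cc2)cc1`, reaches only the limit of > 814000 nM in a functional assay on MCF7 cells (Homo sapiens) for cytotoxicity, read by MTT assay, with a stated time of 24 h; a higher number here means a weaker inhibitor, a lower number a stronger inhibitor.
Compound 2, `COc1ccc(-c2nnc(N3CCN(C(=O)CN4CCN(c5ccc(Cl)cc5)CC4)CC3)nc2-c2ccc(OC)cc2)cc1`, gives 607000 nM in this assay.
Compound 3, `O=C(CN1CCN(c2ccccc2)CC1)N1CCN(c2nnc(-c3ccc(Cl)cc3)c(-c3ccc(Cl)cc3)n2)CC1`, reaches only the limit of > 850000 nM in this assay.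

Compound 3 therefore has no number in this assay, only a limit. Going by the values given here, two of the three values shown are limits (the limit of > 814000 nM in this assay, at which 1 of the 3 values shown sits, (the limit of > 850000 nM in this assay, at which 1 of the 3 values shown sits)), and the single number, given by compound 2, also sits near that end of the scale. Compound 4, `COc1cccc(N2CCN(CC(=O)N3CCN(c4nnc(-c5ccc(Cl)cc5)c(-c5ccc(Cl)cc5)n4)CC3)CC2)c1`, differs from compound 3 by methoxy in place of hydrogen on an aromatic carbon. Among the compounds with values here, the only measured step between compounds that differ in one place is an at least 1.3-fold lower number from compound 1 to compound 2 (0.12 log units; that floor lies within the scatter); it moves a chloro group on a phenyl of the same kind and stays within the scatter, and it does not involve a methoxy group, so it bears only loosely on the present change. Within the data shown here, nothing among the measured compounds points to a shift beyond the scatter in this assay in either direction. The step expected is a step that the limit leaves unreadable from compound 3 to compound 4, meaning no change beyond the scatter. Compound 4 is accordingly expected to give about 900000 nM in this assay, within a range from 400000 nM to 2000000 nM, and most likely to be reported again only as a limit.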

Compound 4, half-maximal inhibitory concentration: 149000 nM
Compound 4: the middle estimate sits 6.0-fold (0.78 log units) above what was measured; measured number outside the range, below it.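

The change from phenyl to 3-methoxyphenyl gives an at least 5.7-fold lower number from compound 3 to compound 4 (0.75 log units; beyond the scatter) in this assay, the first step among these compounds to pass the usual scatter, and it yields a measured number where compound 3 has none. Compound 3 has only a limit, so this step is a floor and the true gap may be larger: the limit of > 850000 nM in this assay, at which 1 of the 4 values shown sits. Going by these compounds alone, this place on the aromatic ring, meta to a large group, therefore responds to what it carries, which the one earlier step could not show, since an at least 1.3-fold lower number from compound 1 to compound 2 (0.12 log units; that floor lies within the scatter) moved a chloro group on a different compound pair and gave nothing beyond the scatter.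

The compounds shown do not tell whether the gain depends on the methoxy group itself, which a hydroxyl, a methyl or an ethoxy at the same place would help to settle, or on its place, which a 4-methoxyphenyl would test. They also leave open why the change has this effect, and whether the same methoxy would do the same on the core of compound 1.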